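Hydroxy at the Benzimidazole-Free Core Position of Compound 2

A few compounds are considered here, and "the series" means these few. Any claim that something is new, unique, unknown or untested is made for them only; others in the source may bear on it.

Three compounds share one core. Compound 1 `Cc1nn2c(-c3nc4cc(C(F)(F)F)ccc4[nH]3)c(-c3ccccc3)nc2s1` gives 3900 nM in a functional assay on ME-180 cells (Homo sapiens) for antiproliferative activity, read by MTT assay; a lower number here means a stronger inhibitor, a higher number a weaker inhibitor. Compound 2 `Cc1nn2c(-c3nc4ccccc4[nH]3)c(-c3ccccc3)nc2s1` gives 16900 nM, and compound 3 `Cc1nn2c(-c3nc4ccccc4[nH]3)c(-c3ccc(F)cc3)nc2s1` gives 18100 nM. Compound 2 thus holds the second highest number of the three; its nearest neighbour is compound 3, a gap that lies within the scatter, while the step of a 4.3-fold higher number from compound 1 to compound 2 (0.64 log units; beyond the scatter) lies beyond it.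

Compound 4 `Cc1nn2c(-c3nc4cc(O)ccc4[nH]3)c(-c3ccccc3)nc2s1` differs from compound 2 in one place: hydroxy in place of hydrogen on an aromatic carbon. Going by the values given here, the hydroxy group enters at the aromatic carbon where compound 1 carries its trifluoromethyl group, so the step of a 4.3-fold higher number from compound 1 to compound 2 (0.64 log units; beyond the scatter) is the one measured change that bears on this position: removing trifluoromethyl there raised the number modestly. The other measured step, a 1.1-fold higher number from compound 2 to compound 3 (0.03 log units; within the scatter), concerns the other aryl ring and lies within the scatter, so it says little here. Going by these compounds, no hydroxy group appears among the measured compounds, so how far a substituent other than trifluoromethyl at this position moves the number is unknown.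

Compound 4 is therefore expected to give a number near that of compound 2, perhaps somewhat lower, with a 1.4-fold lower number from compound 2 to compound 4 (0.15 log units; within the scatter) as the expected step. The estimate for compound 4 is 12000 nM, within a range from 4500 nM to 32000 nM.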

Compound 4, half-maximal inhibitory concentration: 16400 nM
Estimate against measurement, compound 4: 1.4-fold (0.14 log units) below, and the stated range covers the measured number.
By their numbers in this assay, from the lowest: compound 1; then compounds 4, 2 and 3 (each within the scatter of the next).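

In this assay, going by these compounds alone, the step of a 1.0-fold lower number from compound 2 to compound 4 (0.01 log units; within the scatter) lies within the scatter, so at this aromatic carbon hydroxy cannot be told apart from hydrogen, which the earlier compounds could not show. The step of a 4.2-fold higher number from compound 1 to compound 4 (0.62 log units; beyond the scatter) lies beyond the scatter, as does a 4.3-fold higher number from compound 1 to compound 2 (0.64 log units; beyond the scatter), so of the three groups seen at this carbon, only trifluoromethyl gives a number set apart from the others, and a hydroxy group there does not share the lower number of compound 1. No measurement shown here explains this difference between the groups.

The compounds shown leave open whether an amine, a methoxy group, a chlorine atom or a carboxylic acid at this carbon would give a number that stands with compound 1 or with compounds 2 and 4, and so whether the lower number belongs to trifluoromethyl alone. They also leave open whether hydroxy at this carbon would behave the same way alongside the fluoro group of compound 3, or alongside a longer chain in place of the methyl group of the shared core.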